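The source may report more compounds than this note shows. Statements on the series, on what has been measured and on what is new or still open speak of the compounds shown alone.

Compound 1 `C[C@@H](Sc1nc2c(cnn2C)c(=O)n1-c1ccccc1)c1ccccc1` gives 34 nM in an assay on isolated protein for inhibition of Retinaldehyde dehydrogenase 3 (Homo sapiens) (on this read-out higher numbers stand for weaker inhibition and lower numbers for stronger inhibition), the lowest number of the two measured compounds; compound 2 `CC(Oc1nc2c(cnn2C)c(=O)n1-c1ccccc1)c1ccccc1` gives 600 nM, a gap that lies beyond the usual scatter. Compound 3 `CC(Sc1nc2c(cnn2C)c(=O)n1-c1ccccc1)c1cncnc1` keeps the sulfur link of compound 1 and changes the side chain: 1-(pyrimidin-5-yl)ethyl in place of 1-phenylethyl on a sulfur. Among the compounds with values here, no measured pair shows this kind of change, so its effect cannot be read from the series. Going from compound 1 to compound 3, a small weakening is expected, a 2.4-fold higher number from compound 1 to compound 3 (0.37 log units; beyond the scatter), with no confidence that it exceeds the scatter. For compound 3 the estimate is 80 nM, within a range from 25 nM to 300 nM.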

Compound 3, half-maximal inhibitory concentration: 100 nM
Estimate against measurement, compound 3: 1.3-fold (0.10 log units) below; the measured number falls inside the stated range.
By their numbers in this assay, from the lowest: compound 1; then compound 3; then compound 2.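

On a sulfur, the aromatic ring of the side chain can take two ring nitrogens and inhibition persists: in this assay, 1-(pyrimidin-5-yl)ethyl in place of 1-phenylethyl gives a modest loss (a 2.9-fold higher number from compound 1 to compound 3 (0.47 log units; beyond the scatter)). The step also drops the defined stereocentre of compound 1, so the ring change is not cleanly isolated. Nothing on hand accounts for the size of this step.

Still open, on these data alone, is how a single-nitrogen pyridyl ring, or a phenyl ring carrying an amine or a carboxylic acid, would read at this position. As far as these compounds go, the separate contributions of the two stereoisomers of compound 3 also remain open.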